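A Pyrazole for an Oxazole on a Silent Scaffold

The source may report more compounds than this note shows. Statements on the series, on what has been measured and on what is new or still open speak of the compounds shown alone.

Compound 1: `Cc1ccc2c(c1NS(C)(=O)=O)CCC2c1ncc[nH]1` — > 10000 nM
Compound 2: `Cc1oncc1-c1cccc2c1CCC2c1ncc[nH]1` — > 10000 nM
Compound 3: `CCS(=O)(=O)Nc1cccc(Cc2c[nH]cn2)c1` — > 10000 nM

All three measured compounds were tested in a functional assay on CHO cells for agonist activity at Alpha-1D adrenergic receptor (Homo sapiens), read by FLIPR and calcium flux (on this read-out higher numbers stand for an effect only at larger amounts of compound and lower numbers for an effect already at smaller amounts), and none gave a number. Compound 1 sits at the limit of the assay with > 10000 nM. Compound 2 likewise sits at the limit with > 10000 nM. Compound 3 also reaches only the limit with > 10000 nM. Compound 2 therefore stands nowhere in particular on the numbers shown: it shares the limit of > 10000 nM in this assay, at which 3 of the 3 values shown sit, with the other two, and no ordering among them can be read from this.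

The step from compound 2 to the unmeasured compound 4, `Cn1nccc1-c1cccc2c1CCC2c1ncc[nH]1`, consists of 1-methyl-1H-pyrazol-5-yl in place of 5-methyl-1,2-oxazol-4-yl on an aromatic carbon. The two groups match in heavy-atom count, ring size, donor and acceptor count and charge, and the change sits on the same aromatic carbon of the core of compound 2.

Among the compounds with values here, since every value shown is a limit, no measured step exists from which the size or direction of this change could be gauged. Compound 4 is expected to remain at the limit, and the expected step that the limit leaves unreadable from compound 2 to compound 4 would be none beyond the scatter. The estimate for compound 4 in this assay is 20000 nM, with a range from 5000 nM to 100000 nM, because compound 2 gives > 10000 nM.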

Compound 4, half-maximal effective concentration: > 10000 nM
Compound 4 ended at the assay's limit; the forecaster's own chance of this, stated with the estimate: 85%; the middle value does not contradict the limit.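

In this assay compound 4 gives > 10000 nM as a limit of the assay, not a number. Within the data shown here, compound 2 also stands at a limit, so no step between compound 2 and compound 4 can be read. The compounds shown leave open any ordering among them and what any group changes in this assay: the limit of > 10000 nM in this assay, at which 4 of the 4 values shown sit.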